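The source may report more compounds than this note shows. Statements on the series, on what has been measured and on what is new or still open speak of the compounds shown alone.

Measured so far in a functional assay on HUVEC cells (Homo sapiens) for inhibition, read by ELISA; a lower number here means a stronger inhibitor, a higher number a weaker inhibitor:
- compound 1 `COc1c(C)cnc(C[S+]([O-])c2nnc(-c3ccccc3)o2)c1C` gives 6000 nM as the half-maximal inhibitory concentration
- compound 2 `COc1c(C)cnc(C[S+]([O-])c2nnc(C)o2)c1C` gives 8000 nM as the half-maximal inhibitory concentration

Compound 2 stands level with compound 1, since the two values lie within the scatter of each other and give no order. The next entry is compound 3 `COc1c(C)cnc(C[S+]([O-])c2nnc(-c3ccccc3O)o2)c1C`, which is still unmeasured. Relative to compound 2, it has 2-hydroxyphenyl in place of methyl on an aromatic carbon.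

Going by the values given here, one measured step bears on this change: a 1.3-fold higher number from compound 1 to compound 2 (0.12 log units; within the scatter) (methyl in place of phenyl on an aromatic carbon). Read in reverse, it suggests that the swap between methyl and an unsubstituted phenyl hardly moves the number in this assay at this place. Among the compounds with values here, no measured compound carries the 2-hydroxyphenyl group, so the data do not cover that part of the change and the range has to stay wide. The expected move is a 1.6-fold lower number from compound 2 to compound 3 (0.20 log units; within the scatter) and no shift beyond the scatter is expected. The estimate for compound 3 is 5000 nM (expected range 1500 nM to 12000 nM).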

Compound 3, half-maximal inhibitory concentration: 8000 nM
Estimate against measurement, compound 3: 1.6-fold (0.20 log units) below; low and high end bracket the measured number.
By their numbers in this assay, from the lowest: compounds 1, 2 and 3 (each within the scatter of the next).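

In this assay, 2-hydroxyphenyl in place of methyl gives no change at the digits printed from compound 2 to compound 3 (within the scatter), so a group that adds a six-membered aromatic ring, a hydrogen-bond donor and a hydrogen-bond acceptor still leaves the number within the scatter at this aromatic carbon of the five-membered ring. Hydroxy in place of hydrogen on an aromatic carbon gives a 1.3-fold higher number from compound 1 to compound 3 (0.12 log units; within the scatter), the first reading of that group on its own, and this step also stays within the scatter, so methyl, phenyl and 2-hydroxyphenyl give no order at this place. No available evidence accounts for this flat result.

Open, from the compounds shown here alone, is whether an amine, a carboxylic acid or a longer alkyl chain at this place would take the number beyond the scatter. Also open, going by these compounds, is whether methoxy or fluoro on the phenyl in place of the hydroxy would read differently, and whether a change elsewhere on the shared core would move the number further than any step at this position has.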